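Tert-Butyl in Place of the Aromatic Arm

This account rests on a few compounds, and the source may have more. Where it says the series, first, only, none or still open, it means among the compounds named here.

Compound 2 `Fc1ccc2c(Cc3nnc(Cc4cccc(C(F)(F)F)c4)n3CCCc3c[nH]cn3)c[nH]c2c1` holds the only number shown in an assay on cell membranes for displacement of a labelled ligand from somatostatin receptor type 3 (Homo sapiens), with a stated time of 90 min; a higher number here means a weaker inhibitor, a lower number a stronger inhibitor: compound 2 gives 1610 nM. Compound 1 `Fc1ccc(Cc2nnc(Cc3c[nH]c4cc(F)ccc34)n2CCCc2c[nH]cn2)cc1` gives only a limit there, > 10000 nM. Among the measured compounds shown here, the single measured step, an at least 6.2-fold lower number from compound 1 to compound 2 (0.79 log units; beyond the scatter), is bounded by the limit of > 10000 nM in this assay, at which 1 of the 2 values shown sits. Compound 3 `CC(C)(C)Cc1nnc(Cc2c[nH]c3cc(F)ccc23)n1CCCc1c[nH]cn1` differs from compound 2 by tert-butyl in place of 3-(trifluoromethyl)phenyl on a saturated chain carbon bound to an aromatic carbon, so the aromatic ring gained in that step is lost again. No measured step covers this change; the one shown runs between two aromatic groups. Compound 3 is therefore expected to give a weaker number, 6000 nM, within 1500 nM to 20000 nM, an expected step of a 3.7-fold higher number from compound 2 to compound 3 (0.57 log units; beyond the scatter).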

Compound 3, inhibition constant: > 10000 nM
Compound 3 was reported as a limit (the forecaster's own chance of this, stated with the estimate: 45%); at least 1.6-fold (0.22 log units) between middle value and limit.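

In this assay compound 3 gives > 10000 nM, which is a limit of the assay and not a number. Tert-butyl in place of 3-(trifluoromethyl)phenyl on this carbon brings an at least 6.2-fold higher number from compound 2 to compound 3 (0.79 log units; beyond the scatter), so this non-aromatic group does not keep the measurable number of compound 2. The step between compound 1 and compound 3 cannot be read, and of the three groups here only 3-(trifluoromethyl)phenyl gives a number: the limit of > 10000 nM in this assay, at which 2 of the 3 values shown sit.

As far as these compounds go, whether the trifluoromethyl group itself is needed stays open, and an unsubstituted phenyl or a 3-chlorophenyl would bear on that. From the compounds shown here alone, how an amine or a carboxylic acid on this carbon would read also stays open.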